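A few compounds are considered here, and "the series" means these few. Any claim that something is new, unique, unknown or untested is made for them only; others in the source may bear on it.

The measured compounds:

Compound 1, `COc1ccc(F)cc1CNCCCNc1ccnc2cc(CCC(C)C)ccc12`, in a physicochemical assay for solubility, with a stated time of 18 h, at pH 7.4 (on this read-out lower numbers stand for lower solubility and higher numbers for higher solubility), gives 4200 nM.
Compound 2, `COc1cccc(CNCCCNc2ccnc3cc(-c4ccc(C(F)(F)F)cc4)ccc23)c1O`, in this assay gives 32000 nM.
Compound 3, `COc1ccc(-c2ccc3c(NCCCNCc4ccco4)ccnc3c2)cc1`, in this assay gives 32000 nM.

Compound 2 stands level with compound 3 at the digits shown, and together the two give the highest numbers of the three. Compound 1 lies furthest from compound 2, with a lower number whose gap goes beyond the usual scatter of repeated measurements, so the two can be told apart with some confidence.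

Compound 4, `COc1cccc(CNCCCNc2ccnc3cc(Oc4ccccc4)ccc23)c1O`, has not yet been measured in this assay. It differs from compound 2 in one place: phenoxy in place of 4-(trifluoromethyl)phenyl on an aromatic carbon. The group that leaves is the larger of the two, while the group that enters brings one hydrogen-bond acceptor where there was none before. Among the measured compounds shown here, no pair of measured compounds shows this exact change, so the size of the step has to be guessed rather than read off. A modest rise in solubility, or no change beyond the scatter, seems the more likely outcome; a fall cannot be ruled out.

For compound 4 the expected value is 40000 nM, within the range 15000 nM to 100000 nM. This estimate means a step from compound 2 to compound 4 of a 1.3-fold higher number from compound 2 to compound 4 (0.10 log units; within the scatter), expected to stay small.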

Compound 4, solubility: 14500 nM
Compound 4: middle estimate off by 2.8-fold (0.44 log units), on the high side, outside the stated range (below it).
By their numbers in this assay, from the lowest: compound 1; then compound 4; then compounds 2 and 3 (each within the scatter of the next).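

In this assay, putting phenoxy in place of 4-(trifluoromethyl)phenyl on this aromatic carbon gives a 2.2-fold lower number from compound 2 to compound 4 (0.34 log units; beyond the scatter), a modest step but one that lies beyond the scatter. Among the compounds shown here, this is the first direct sign that the group at this place on the shared core can move the read-out, and here the number falls even though the entering group has fewer heavy atoms and brings a hydrogen-bond acceptor, so those two counts did not point the way for this single pair. No measurement shown here gives an explanation for the drop.

The swap alters two things at once, adding an oxygen link between the core and the ring and removing the trifluoromethyl group, and this one pair cannot divide the step between them; a plain phenyl on the same carbon would sit between the two. Also open, from the compounds shown here alone, is whether a quite different group there, such as an amine or a carboxylic acid, would move the number further, and whether this step keeps its direction and size with other side chains on the core.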